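Dihydropyridine ester variation and an expected calcium-channel result

The source may report more compounds than this note shows. Statements on the series, on what has been measured and on what is new or still open speak of the compounds shown alone.

Measured compounds:
compound 1, `C#CCCOC(=O)C1=C(C)NC(C)=C(C(=O)OC)C1c1cccc([N+](=O)[O-])c1`: 31 nM
compound 2, `C=C(C)CCOC(=O)C1=C(C)NC(C)=C(C(=O)OC)C1c1cccc([N+](=O)[O-])c1`: 23 nM
compound 3, `COC(=O)C1=C(C)NC(C)=C(C(=O)OCC(C)[N+](=O)[O-])C1c1cccc([N+](=O)[O-])c1`: 108 nM

The three compounds share one core and differ only in the ester group. In a functional assay on HEK293 cells for antagonist activity at Voltage-dependent L-type calcium channel subunit alpha-1C (Oryctolagus cuniculus), read by FLIPR (a higher number here means a weaker inhibitor, a lower number a stronger inhibitor), compound 3 gives the highest number of the three: the step of a 3.5-fold higher number from compound 1 to compound 3 (0.54 log units; beyond the scatter) and the step of a 4.7-fold higher number from compound 2 to compound 3 (0.67 log units; beyond the scatter) both lie beyond the scatter, whereas the step of a 1.3-fold lower number from compound 1 to compound 2 (0.13 log units; within the scatter) stays within it. Compound 3 is therefore the weakest inhibitor of the set in this assay.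

Compound 4, `COC(=O)C1=C(C)NC(C)=C(C(=O)OCc2cc([N+](=O)[O-])cc([N+](=O)[O-])c2)C1c1cccc([N+](=O)[O-])c1`, carries the change (3,5-dinitrophenyl in place of 1-nitroethyl on a saturated chain carbon bound to an oxygen next to a carbonyl group). Within the data shown here, no measured step replaces one ester group with an aromatic one, so the two measured steps into compound 3 are the only guide, and they show that the nitroethyl ester raised the number relative to the small unsaturated chains. The new group keeps nitro substituents but sits on an aromatic ring, so compound 4 is expected to land near compound 3, with a wide range in either direction; the estimated step is a 1.5-fold lower number from compound 3 to compound 4 (0.19 log units; within the scatter). The estimate for compound 4 in this assay is 70 nM, with a range from 15 nM to 350 nM.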

Compound 4, half-maximal inhibitory concentration: 55 nM
The estimate for compound 4 lay 1.3-fold (0.10 log units) above the measured number, within the range that was stated.
By their numbers in this assay, from the lowest: compounds 2, 1, 4 and 3 (each within the scatter of the next, the first and the last beyond it).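

In this assay, putting the larger, ring-bearing 3,5-dinitrophenyl in place of 1-nitroethyl on a saturated chain carbon bound to an oxygen next to a carbonyl group gives a 2.0-fold lower number from compound 3 to compound 4 (0.29 log units; within the scatter), so this place accepts an aromatic ring with no change that can be told from the scatter. Against the small unsaturated chains the result is split: the same group in place of propargyl gives a 1.8-fold higher number from compound 1 to compound 4 (0.25 log units; within the scatter), while in place of 2-methylprop-2-en-1-yl it gives a 2.4-fold higher number from compound 2 to compound 4 (0.38 log units; beyond the scatter), a modest step and the only one of the three that clears the scatter. No supporting measurement bears on why these steps have the sizes they do.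

The compounds shown leave open whether the two nitro groups on the ring matter at all, a question that a plain phenyl ring or a ring with a single nitro group in the same place would answer. They also leave open how this place would respond to a chain ending in an amine or a carboxylic acid, or to a longer chain between the ester oxygen and the ring.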